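This account rests on a few compounds, and the source may have more. Where it says the series, first, only, none or still open, it means among the compounds named here.

In a functional assay on T98G cells (Homo sapiens) for inhibition, read by colorimetric assay and MTT assay, with a stated time of 72 h (a higher number here means a weaker inhibitor, a lower number a stronger inhibitor), compound 1 `CCCCOc1ncc(-c2ccccc2OC)n1C` gives 96000 nM. Among the measured compounds shown here, only one other compound has a number so far: compound 2 `COc1ccccc1-c1cnc(OCC(F)(F)C(F)(F)C(F)(F)C(F)(F)C(F)(F)F)n1C` gives 78000 nM. These two values lie within the usual scatter of repeated measurements, so compound 1 stands level with compound 2, and neither can be called the stronger inhibitor.

The next compound, compound 3 `C=CCCOc1ncc(-c2ccccc2OC)n1C`, keeps the core of compound 1 and carries a single change: vinyl in place of ethyl on a saturated chain carbon, two bonds along the chain from an oxygen on an aromatic ring. In plain words, vinyl takes the place of ethyl on a saturated chain carbon, two bonds along the chain from an oxygen on an aromatic ring. The same difference can also be read as butoxy to (but-3-en-1-yl)oxy.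

For the measured compounds named here, no measured pair shows this change directly. Going by the values given here, the only guide is the closeness of compound 2, at 78000 nM, to compound 1, at 96000 nM, so no step beyond the scatter is expected in this assay, in either direction. The estimated change is a 1.1-fold lower number from compound 1 to compound 3 (0.05 log units; within the scatter). For compound 3, the expected value is 85000 nM, with an estimated range from 35000 nM to 170000 nM.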

Compound 3, half-maximal inhibitory concentration: 39000 nM
Estimate against measurement, compound 3: 2.2-fold (0.34 log units) above, within the range that was stated.
By their numbers in this assay, from the lowest: compounds 3, 2 and 1 (each within the scatter of the next, the first and the last beyond it).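

This position on the chain turns out to respond to a small change. In this assay, putting vinyl in place of ethyl on a saturated chain carbon, two bonds along the chain from an oxygen on an aromatic ring, gives a 2.5-fold lower number from compound 1 to compound 3 (0.39 log units; beyond the scatter), a modest step but a real one, since it lies beyond the usual scatter. The group that leaves and the group that enters both have 2 carbon atoms, no ring, no hydrogen-bond donors or acceptors and no net charge, so the one counted difference is the double bond, although no measurement here explains how that double bond produces the step.

From the compounds shown here alone, it remains open whether an ethynyl group, a phenyl ring or an amine at this same place would lower the number further, or raise it again. Going by these compounds, it is also open whether the step depends on where the double bond lies, which a butoxy chain with its double bond moved closer to the oxygen, or a longer chain ending in vinyl, could show.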